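Swapping cyclopropyl for thiophen-2-yl on the shared core

A few compounds are considered here, and "the series" means these few. Any claim that something is new, unique, unknown or untested is made for them only; others in the source may bear on it.

Compound 1 `c1ccc(C(/N=C2\CCCCN2)C2CC2)cc1` gives 36% in a functional assay on the whole organism (plasma, strain Sprague-Dawley) with Rattus norvegicus as the target, with a stated time of 2 h, at a dose of 100 mg/kg by the oral route; on this read-out higher numbers stand for a stronger effect at the one dose given and lower numbers for a weaker effect.
Compound 2 `c1csc(C(/N=C2\CCCCCCN2)C2CC2)c1` gives 50% in this assay.

Among these two numbers compound 1 stands lowest, with compound 2 the nearer neighbour at a gap beyond the scatter. Compound 3 `c1ccc(C(/N=C2\CCCCN2)c2cccs2)cc1` carries thiophen-2-yl in place of cyclopropyl on a saturated chain carbon bound to an aromatic carbon and a double-bonded nitrogen. Going by the values given here, no measured pair shows this change on its own, so the account rests on compound 1 alone. A step from compound 1 to compound 3 is expected to stay within the scatter, with no clear direction, as a number 4 percentage points higher from compound 1 to compound 3 (within the scatter). Compound 3 is therefore estimated at 40%, between 15% and 65%.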

Compound 3, a percentage reported as inhibition, in the whole organism at one dose (the size of the read-out at that dose, not a potency): 32%
Estimate against measurement, compound 3: 8 percentage points above; the range from low to high includes it.
By their numbers in this assay, from the lowest: compounds 3 and 1 (each within the scatter of the next); then compound 2.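

In this assay, thiophen-2-yl in place of cyclopropyl on a saturated chain carbon bound to an aromatic carbon and a double-bonded nitrogen gives a number 4 percentage points lower from compound 1 to compound 3 (within the scatter). This first single-place comparison shows that, at this position, the five-membered aromatic ring with its sulfur and the three-membered carbon ring cannot be told apart on this read-out. No measurement at hand offers a reason for this result. As far as these compounds go, whether an amine, a carboxylic acid or a longer chain at this position would shift the read-out beyond the scatter remains open. So does whether the same swap would read alike on the core of compound 2.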